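The source may report more compounds than this note shows. Statements on the series, on what has been measured and on what is new or still open speak of the compounds shown alone.

Working notes on the series. In a functional assay on HT-29 cells (Homo sapiens) for inhibition (on this read-out higher numbers stand for weaker inhibition and lower numbers for stronger inhibition), compound 1 `CCCCCCCCCCCCCCCCCCOC[C@H](COP(=O)(O)O[C@@H]1[C@H](O)[C@@H](CO)[C@@H](O)[C@H](O)[C@@H]1O)OC` gives 7500 nM and compound 2 `CCCCCCCCCCCCCCCCCCOC[C@H](COC(=O)O[C@@H]1[C@H](O)[C@@H](CO)[C@@H](O)[C@H](O)[C@@H]1O)OC` gives 12000 nM as its value. Going by the values given here, these two numbers lie within the usual scatter of each other, so compound 1 cannot be separated from the only other measured compound. Compound 3 `CCCCCCCCCCCCCCCCCCOC[C@H](COP(=O)(O)O[C@@H]1[C@H](O)[C@H](CO)[C@@H](O)[C@H](O)[C@@H]1O)OC` has the same atoms and bonds as compound 1, and the difference is the two compounds have the same atoms and bonds; at least one stereo element is drawn with a configuration in one of them and without one in the other: 1 of 8 stereo elements differ; a stereocentre at a saturated ring carbon is drawn S in compound 1 and R in compound 3 in the shared core: a stereocentre at a saturated ring carbon is drawn S in compound 1 and R in compound 3. Among the compounds with values here, no measured pair yet shows the size of such a change in this assay and the expectation is therefore loose. No move beyond the scatter is expected, with any drift towards a higher number. The estimated 1.3-fold higher number from compound 1 to compound 3 (0.12 log units; within the scatter) is small and uncertain. Compound 3 is expected at 10000 nM with an estimated range of 4000 nM to 25000 nM in this read-out.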

Compound 3, half-maximal inhibitory concentration: 4500 nM
Estimate against measurement, compound 3: 2.2-fold (0.35 log units) above; low and high end bracket the measured number.
By their numbers in this assay, from the lowest: compounds 3, 1 and 2 (each within the scatter of the next, the first and the last beyond it).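

The first measured size for this kind of change comes from the saturated ring carbon: in this assay, the change in drawn configuration at this position gives a 1.7-fold lower number from compound 1 to compound 3 (0.22 log units; within the scatter), with all other atoms and bonds shared. The two configurations at this stereocentre are therefore not separated by this read-out, and neither can be preferred on these numbers. One point about the drawings limits how firmly the step can be read as a comparison of two defined configurations: the fact that one of compounds 1 and 3 is drawn with a defined configuration and the other without, at the place where they differ.

From the compounds shown here alone, it remains open whether the same change in configuration would give a step of similar size on the shared core of compound 2. Also open, going by these compounds, is whether an amine or a carboxylic acid at this ring carbon, or a longer chain, would give a step beyond the scatter.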